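The compounds below may be only part of what the source reports. "The series", "measured", "known", "first", "only" and "open" are said of these compounds alone.

Working notes on the series in a functional assay on MT2 cells (Homo sapiens) for cytotoxicity, read by MTT assay; a lower number here means that less compound is tolerated, a higher number that more compound is tolerated.

Of the compounds shown here, three of the shared core have numbers so far. Compound 1 `Clc1ccc(Nc2nnc(Cc3c(Cl)cccc3Cl)o2)cc1` gives 20000 nM in this assay. Compound 2 `Clc1ccc(Nc2nnc(Cc3ccccc3)o2)cc1` gives 31000 nM. Compound 3 `FC(F)(F)c1cc(Nc2nnc(Cc3c(Cl)cccc3Cl)o2)ccc1Cl` gives 9000 nM, the lowest of the three: compound 1 stands nearest to it and compound 2 furthest, and both gaps are beyond the scatter. Going by the values given here, the one single-point step among the measured compounds is a 2.2-fold lower number from compound 1 to compound 3 (0.35 log units; beyond the scatter), so the arrival of the trifluoromethyl group on the ring that also carries the chloro group was accompanied by a modest fall in the tolerated concentration.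

Compound 4 `Cc1cc(Nc2nnc(Cc3c(Cl)cccc3Cl)o2)ccc1Cl` is the next structure, not yet measured. Relative to compound 3 it shows (methyl in place of trifluoromethyl on an aromatic carbon). Among the compounds with values here, the only measured step that bears on this change is the one from compound 1 to compound 3, since it concerns the same aromatic carbon; a methyl sits structurally between hydrogen and trifluoromethyl at that carbon, so the step back from compound 3 to compound 4 is expected to run in the opposite direction, partly reversing the fall seen there, and to be modest at most, with a real chance it stays within the scatter. The expected step is a 1.6-fold higher number from compound 3 to compound 4 (0.19 log units; within the scatter). Compound 4 is estimated at 14000 nM in this assay, in the range 7000 nM to 30000 nM.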

Compound 4, half-maximal cytotoxic concentration: > 100000 nM
Compound 4 gave a limit, no number (the forecaster's own chance of this, stated with the estimate: 5%); middle value at least 7.1-fold (0.85 log units) from the limit.
By their numbers in this assay, from the lowest: compound 3; then compounds 1 and 2 (each within the scatter of the next). At a limit, above all of these: compound 4.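

Compound 4 stands at > 100000 nM in this assay, and this is a limit of the assay, not a number. At this aromatic carbon, ortho to a chloro group, methyl in place of trifluoromethyl gives an at least 11-fold higher number from compound 3 to compound 4 (1.04 log units; beyond the scatter), and methyl in place of hydrogen gives an at least 5.0-fold higher number from compound 1 to compound 4 (0.69 log units; beyond the scatter). The earlier compounds showed only that trifluoromethyl stood lower than hydrogen here, whereas methyl now stands above both, so the three groups do not fall in the order that the single earlier step suggested, and both new steps give only a minimum size: the limit of > 100000 nM in this assay, at which 1 of the 4 values shown sits.

The compounds shown leave open whether the rise belongs to methyl alone or would also appear with an ethyl group, a methoxy group, an amine or a fluorine at this carbon. They also do not settle why the number changes at this position, or whether the same step would hold on the core of compound 2, which lacks the two chloro groups on its other ring.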